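Allyl Ether Replacing Hemisuccinate on the Chroman Core

This account rests on a few compounds, and the source may have more. Where it says the series, first, only, none or still open, it means among the compounds named here.

Measured compounds:
- Compound 1, `CC(C)=CCOc1c(C)c(C)c2c(c1C)CCC(C)(COc1ccc(/C=C3\SC(=O)NC3=O)cc1Br)O2`: 84%
- Compound 2, `Cc1c(C)c2c(c(C)c1OC(=O)CCC(=O)O)CCC(C)(COc1ccc(/C=C3\SC(=O)NC3=O)cc1)O2`: 98%
- Compound 3, `C=CCOc1c(C)c(C)c2c(c1C)CCC(C)(COc1cccc(/C=C3\SC(=O)NC3=O)c1)O2`: 92%

In a functional assay on MCF7 cells (Homo sapiens), tested at 5 uM (on this read-out higher numbers stand for a weaker effect at the one concentration tested and lower numbers for a stronger effect), compound 2 gives the highest number of the three, that is the weakest effect. Compound 3 lies close to it, within the usual scatter, so no order between these two can be claimed. Compound 1 sits further off, beyond the scatter, and so shows a clearer effect than compound 2 at this concentration.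

Compound 4, `C=CCOc1c(C)c(C)c2c(c1C)CCC(C)(COc1ccc(/C=C3\SC(=O)NC3=O)cc1)O2`, has not yet been tested. It differs from compound 2 in one place: allyl in place of (2-carboxyethyl)carbonyl on an oxygen on an aromatic ring. Compound 3 carries the same allyl ether on the same core and gives 92% in this assay, so a number in that neighbourhood is the natural expectation for compound 4. The step of a number 8 percentage points lower from compound 2 to compound 4 (within the scatter) is therefore expected to be small, pointing towards a somewhat stronger effect but likely still within the scatter. Compound 4 is expected to give about 90%, with a range from 78% to 100%.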

Compound 4, a percentage reported as activity, at one concentration (the size of the read-out at that concentration, not a potency): 42%
Compound 4: the middle estimate sits 48 percentage points above what was measured, and the stated range ends above it.
By their numbers in this assay, from the lowest: compound 4; then compounds 1, 3 and 2 (each within the scatter of the next, the first and the last beyond it).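

In this assay, allyl in place of (2-carboxyethyl)carbonyl on this oxygen gives a number 56 percentage points lower from compound 2 to compound 4 (beyond the scatter), the first sign that the read-out can move far with a change at this position. The allyl ether alone does not settle the result: compound 3 carries the same group on the same core and differs from compound 4 in one other place, yet compound 3 stands at 92% in this assay. Nothing measured here accounts for the size of this step.

Going by these compounds, whether a saturated propyl chain or a benzyl group on this oxygen would keep the stronger effect remains open. Compound 1 differs from compound 4 in more than one place, so the separate contributions of its bromine and its ether group cannot be read.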